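Group on the aromatic nitrogen: compound 4

The source may hold more compounds than are shown below. What is called first, only, known or untested is meant among the compounds shown, and "the series" means these compounds.

Compound 1 `CCC(CC)n1c(-c2ccc(OCc3c(-c4c(Cl)cccc4Cl)noc3C(C)C)cc2)nc2ccc(C(=O)O)cc21` carries pentan-3-yl on the aromatic nitrogen and in an assay on Huh-7 cells for agonist activity at Bile acid receptor (Homo sapiens), read by a luciferase reporter (on this read-out lower numbers stand for an effect already at smaller amounts and higher numbers for an effect only at larger amounts of compound), compound 1 gives 0.8 nM. Compound 2 `CC(C)c1onc(-c2c(Cl)cccc2Cl)c1COc1ccc(-c2nc3ccc(C(=O)O)cc3n2CC(C)(C)C)cc1` carries neopentyl there and gives 13 nM; compound 3 `CC(C)Cn1c(-c2ccc(OCc3c(-c4c(Cl)cccc4Cl)noc3C(C)C)cc2)nc2ccc(C(=O)O)cc21` carries isobutyl and gives 5.26 nM. Among these three numbers compound 3 stands second highest: the nearer neighbour is reached by the step of a 2.5-fold lower number from compound 2 to compound 3 (0.39 log units; beyond the scatter), the further one by the step of a 6.6-fold higher number from compound 1 to compound 3 (0.82 log units; beyond the scatter); the remaining step is a 16-fold higher number from compound 1 to compound 2 (1.21 log units; beyond the scatter).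

Compound 4 `CC(=O)N1CCC(n2c(-c3ccc(OCc4c(-c5c(Cl)cccc5Cl)noc4C(C)C)cc3)nc3ccc(C(=O)O)cc32)CC1` differs from compound 3 by 1-acetylpiperidin-4-yl in place of isobutyl on an aromatic nitrogen. All three measured steps bear on this change, since each of them also exchanges only the group on the same aromatic nitrogen; they span from a modest to a large shift, with the lowest number at pentan-3-yl in compound 1 and the highest at neopentyl in compound 2. Among the compounds with values here, the entering group is larger than any of the three alkyl groups and brings a ring and an acceptor, for which no measured step exists. Compound 4 is therefore expected to give 3 nM, within 0.8 nM to 12 nM. The expected step of a 1.8-fold lower number from compound 3 to compound 4 (0.24 log units; within the scatter) is estimated to lie roughly within the scatter, leaning towards a lower number.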

Compound 4, half-maximal effective concentration: 1430 nM
For compound 4 the middle estimate is 480-fold (2.68 log units) below the measured one, and the stated range ends below it.
By their numbers in this assay, from the lowest: compound 1; then compound 3; then compound 2; then compound 4.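

In this assay this aromatic nitrogen proves far less permissive than the three alkyl groups suggested: 1-acetylpiperidin-4-yl in place of isobutyl gives a 270-fold higher number from compound 3 to compound 4 (2.43 log units; beyond the scatter) and the same group gives a 110-fold higher number from compound 2 to compound 4 (2.04 log units; beyond the scatter) and also a 1800-fold higher number from compound 1 to compound 4 (3.25 log units; beyond the scatter). Each of these steps is larger than any step among pentan-3-yl, neopentyl and isobutyl, so the differences among those alkyl groups are small beside what this single exchange does, and compound 4 stands alone at the high end of the series. The entering group differs from the leaving isobutyl at once in heavy atoms, in its six-membered non-aromatic ring and in its hydrogen-bond acceptor, and nothing at hand says which of these accounts for the shift.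

Still open, as far as these compounds go, is whether the large rise in the number goes with the ring itself or with the acetyl group on its nitrogen. A cyclohexyl group, a piperidin-4-yl with a free amine, or a tetrahydropyran-4-yl on the same aromatic nitrogen would separate these two parts of the change.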